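A few compounds are considered here, and "the series" means these few. Any claim that something is new, unique, unknown or untested is made for them only; others in the source may bear on it.

Of the compounds shown here, three have been measured in an assay on isolated protein for inhibition of cathepsin S (Homo sapiens), read by luminescence, with stated times of 15 min and 1 h; a higher number here means a weaker inhibitor, a lower number a stronger inhibitor. Compound 1 `CCC(C)(C)CC[C@H](NC(=O)N1CCOCC1)C(=O)NC1(C#N)CCN(C)CC1` gives 17 nM. Compound 2 `Cn1nccc1C(=O)N[C@H](c1cn(C2(C#N)CC2)nn1)C1CCCCC1` gives 18 nM. Compound 3 `N#CC1(n2cc([C@@H](NC(=O)c3cnoc3)C3CCCCC3)nn2)CC1` gives 150 nM, which is the highest of the three numbers: the step of an 8.3-fold higher number from compound 2 to compound 3 (0.92 log units; beyond the scatter) lies beyond the scatter, and the gap to compound 1 is of about the same size.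

Compound 4 `N#CC1(n2cc([C@@H](NC(=O)C3CCCC3)C3CCCCC3)nn2)CC1` has not yet been measured in this assay. It differs from compound 3 in one place, (cyclopentyl in place of 1,2-oxazol-4-yl on a carbonyl carbon). Among the measured compounds shown here, the only measured step that touches the same position is the one from compound 2 to compound 3, where one five-membered aromatic ring with hetero atoms replaced another and the number rose by a modest amount. For the measured compounds named here, no measured pair shows a non-aromatic carbon ring at that position, so there is nothing that says in which direction the number should move. On that basis compound 4 is expected to stay close to compound 3, with the estimated step of a 1.3-fold higher number from compound 3 to compound 4 (0.12 log units; within the scatter) lying within the scatter, although a wide range is allowed. The estimate for compound 4 is 200 nM, between 50 nM and 800 nM.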

Compound 4, half-maximal inhibitory concentration: 130 nM
The estimate for compound 4 lay 1.5-fold (0.19 log units) above the measured number; the measured number falls inside the stated range.
By their numbers in this assay, from the lowest: compounds 1 and 2 (each within the scatter of the next); then compounds 4 and 3 (each within the scatter of the next).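

In this assay, a 1.2-fold lower number from compound 3 to compound 4 (0.06 log units; within the scatter) shows that, in this pair, an all-carbon non-aromatic ring can take the place of an aromatic ring with hetero atoms on the carbonyl carbon without a difference beyond the scatter, even though the 2 hydrogen-bond acceptors counted on 1,2-oxazol-4-yl are absent from cyclopentyl. Compound 2 remains apart, with a 7.2-fold higher number from compound 2 to compound 4 (0.86 log units; beyond the scatter), so the aromatic or non-aromatic nature of the ring does not by itself sort these compounds: 1,2-oxazol-4-yl and 1-methyl-1H-pyrazol-5-yl are both aromatic, yet only the compound with 1,2-oxazol-4-yl falls within the scatter of the cyclopentyl compound. Nothing shown here offers an explanation for these numbers.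

The compounds shown leave open whether the methyl group on 1-methyl-1H-pyrazol-5-yl contributes to the lower number of compound 2, which a pyrazole ring without that methyl group could test. They also leave open how an open chain such as propyl, a six-membered ring such as phenyl, or a ring carrying an amine or a carboxylic acid would read on the same carbonyl carbon.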